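Aryl swap on the sulfonyl of a series level in this assay

The compounds below may be only part of what the source reports. "The series", "measured", "known", "first", "only" and "open" are said of these compounds alone.

Compound 1 `Nc1nc2c(c(=O)n(CC3CC3)c(=O)n2CC2CC2)n1Cc1cccc2ccccc12`: 0%
Compound 2 `Nc1nc2c(c(=O)n(CC3CC3)c(=O)n2CC2CC2)n1S(=O)(=O)c1ccc(C(F)(F)F)cc1`: 0%

In an assay on isolated protein with dual specificity calcium/calmodulin-dependent 3',5'-cyclic nucleotide phosphodiesterase 1B (Bos taurus) as the target, tested at 100 uM (on this read-out higher numbers stand for more inhibition at the one concentration tested (going by the name of the read-out) and lower numbers for less inhibition), compound 1 gives 0%. Compound 2 gives 0% in this assay and stands level with compound 1 at the digits shown, within the scatter. Compound 3 `COc1ccc(S(=O)(=O)n2c(N)nc3c2c(=O)n(CC2CC2)c(=O)n3CC2CC2)cc1OC` differs from compound 2 in one place: 3,4-dimethoxyphenyl in place of 4-(trifluoromethyl)phenyl on a sulfonyl sulfur. For the measured compounds named here, no measured pair informs this change, so the step of a number 2 percentage points higher from compound 2 to compound 3 (within the scatter) is expected to stay within the scatter, with no direction beyond it. Compound 3 is estimated at 2%, in the range -8% to 15%.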

Compound 3, a percentage reported as inhibition, at one concentration (the size of the read-out at that concentration, not a potency): 56%
Compound 3: the middle estimate sits 54 percentage points below what was measured; measured number outside the range, above it.
By their numbers in this assay, from the lowest: compounds 1 and 2 (each within the scatter of the next); then compound 3.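

In this assay the aryl group on a sulfonyl sulfur proves able to change the read-out: 3,4-dimethoxyphenyl in place of 4-(trifluoromethyl)phenyl gives a number 56 percentage points higher from compound 2 to compound 3 (beyond the scatter) with the rest of the structure unchanged. The entering group differs by its oxygen atoms and hydrogen-bond acceptors, though the heavy-atom count stays the same. No measurement on hand accounts for the step.

Still open, from the compounds shown here alone, is whether a single methoxy group on the phenyl ring would hold this level, and how an amine or a carboxylic acid there would read.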